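Methoxy in Place of Methyl on the Anilino Ring

The compounds below may be only part of what the source reports. "The series", "measured", "known", "first", "only" and "open" are said of these compounds alone.

Of the compounds shown here, two have been measured in a functional assay on L1210 cells (Mus musculus) for antiproliferative activity, read by cell counting, with a stated time of 2 days; a lower number here means a stronger inhibitor, a higher number a weaker inhibitor. Compound 1 `Cc1ccc(Nc2nc(-n3ccnc3C)cs2)cc1` gives 1800 nM, whereas compound 2 `COc1cc(C(=O)c2sc(Nc3ccc(C)cc3)nc2N)cc(OC)c1OC` gives 31 nM. Compound 2 therefore stands at the lowest number of the two, and its gap to compound 1 lies well beyond the scatter.

The unmeasured compound 3 `COc1ccc(Nc2nc(N)c(C(=O)c3cc(OC)c(OC)c(OC)c3)s2)cc1` keeps the shared core of compound 2 and differs from it in one place: methoxy in place of methyl on an aromatic carbon. Among the measured compounds shown here, no pair of measured compounds isolates this change, so nothing here tells how much methoxy in place of methyl on an aromatic carbon alters the read-out.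

Compound 3 is expected to give about 25 nM in this assay, within a range of 8 nM to 80 nM. The estimated step of a 1.2-fold lower number from compound 2 to compound 3 (0.09 log units; within the scatter) is expected to be small, with no direction clear beyond the scatter.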

Compound 3, half-maximal inhibitory concentration: 1500 nM
Compound 3: middle estimate off by 60-fold (1.78 log units), on the low side; measured number outside the range, above it.
By their numbers in this assay, from the lowest: compound 2; then compounds 3 and 1 (each within the scatter of the next).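

In this assay, the change from (4-methylphenyl)amino to (4-methoxyphenyl)amino gives a 48-fold higher number from compound 2 to compound 3 (1.68 log units; beyond the scatter), so this position, para to a large group, does not accept methoxy in place of methyl without a heavy loss of activity. The swap adds only one carbon-to-oxygen link and one hydrogen-bond acceptor, yet this single change moves the read-out far beyond the scatter, which shows that the read-out depends strongly on what sits at this place. No measurement available here bears on why the number rises.

The compounds shown leave open whether the oxygen or the added size of the group matters more, which an ethyl group, a hydroxyl or a chlorine at the same place could begin to separate. They also leave open whether methoxy in place of methyl would cost as much on another core.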